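Trading a benzyl group for a short branched chain

A few compounds are considered here, and "the series" means these few. Any claim that something is new, unique, unknown or untested is made for them only; others in the source may bear on it.

In an ADME assay on HepG2 cells (Homo sapiens) for cytotoxicity, read by luminescence, CellTiter-Glo and ATP content, with a stated time of 72 h (on this read-out higher numbers stand for an effect only at larger amounts of compound and lower numbers for an effect already at smaller amounts), three compounds with a shared core have been measured. Compound 1 `COc1ccc(F)cc1CNCCCNc1ccnc2cc(Cc3cc(C)cc(C)c3)ccc12` gives 940 nM. Compound 2 `Cc1cc(C)cc(Cc2ccc3c(NCCCNCc4ccco4)ccnc3c2)c1` gives 6270 nM, and compound 3 `COc1ccc(F)cc1CNCCCNc1ccnc2cc(-c3cccc4ccccc34)ccc12` gives 16000 nM. Compound 2 thus holds the middle position of the three: its number lies above that of compound 1, as the step of a 6.7-fold higher number from compound 1 to compound 2 (0.82 log units; beyond the scatter) shows, and below that of compound 3.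

Compound 4 `CCC(CC)c1ccc2c(NCCCNCc3ccco3)ccnc2c1` has not yet been measured. It differs from compound 2 in one place: pentan-3-yl in place of 3,5-dimethylbenzyl on an aromatic carbon

The step that bears most on this change is a 17-fold higher number from compound 1 to compound 3 (1.23 log units; beyond the scatter), since it also exchanges the 3,5-dimethylbenzyl group on the same aromatic carbon of the core. That exchange gave a large rise. Going by the values given here, no measured step covers a pentan-3-yl group, so the direction is uncertain, but a rise beyond the scatter seems the more likely outcome.

Compound 4 is therefore expected to give about 12000 nM in this assay, within a range of 4000 nM to 40000 nM, an expected step of a 1.9-fold higher number from compound 2 to compound 4 (0.28 log units; within the scatter).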

Compound 4, half-maximal effective concentration: 6760 nM
For compound 4 the middle estimate is 1.8-fold (0.25 log units) above the measured one; low and high end bracket the measured number.
By their numbers in this assay, from the lowest: compound 1; then compounds 2 and 4 (each within the scatter of the next); then compound 3.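

At this aromatic carbon of the shared core, replacing 3,5-dimethylbenzyl with pentan-3-yl in this assay gives a 1.1-fold higher number from compound 2 to compound 4 (0.03 log units; within the scatter), so a smaller group with no ring cannot be told apart from the larger one on this read-out. The earlier change at the same carbon, a 17-fold higher number from compound 1 to compound 3 (1.23 log units; beyond the scatter), put in naphthalen-1-yl on a compound with a different side chain, so losing 3,5-dimethylbenzyl does not by itself bring a large step. Nothing measured here gives a reason for this result.

Going by these compounds, it remains open whether pentan-3-yl would behave the same way in compound 1, which carries the 5-fluoro-2-methoxyphenyl group in place of the furan-2-yl group. Also open, on these data alone, is what an amine or a carboxylic acid at this carbon would do.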